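The compounds below may be only part of what the source reports. "The series", "measured", "known", "first", "only" and "open" are said of these compounds alone.

Measured compounds in the series:

compound 1 `CN1CCCc2ccc(NC(=O)c3ccc(-c4ccccc4)cc3)cc21`: 7.5
compound 2 `Cc1ccc2ccc(NC(=O)c3ccc(-c4ccccc4)cc3)cc2n1`: 8
compound 3 `CN1CCCc2ccc(NC(=O)c3ccc(-c4cccs4)cc3)cc21`: 7.6

In a functional assay for antagonist activity at transient receptor potential cation channel subfamily V member 1 (Homo sapiens), read by FLIPR and calcium flux (a lower number here means a less potent compound, a higher number a more potent compound, by a factor of ten per unit of this negative logarithm), compound 3 stands second highest of the three numbers. Its nearest neighbour is compound 1, whose value in this assay is lower by an amount within the scatter; the furthest is compound 2, whose value is higher by an amount beyond the scatter. Among the compounds with values here, compound 2 carries a different core, so no single-point step connects it to compound 3.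

The next compound, compound 4 `CN1CCCc2ccc(NC(=O)c3ccc(-c4cncnc4)cc3)cc21`, differs from compound 3 by pyrimidin-5-yl in place of thiophen-2-yl on an aromatic carbon.

Within the data shown here, only one measured step touches the same aromatic carbon: the exchange of phenyl for thiophen-2-yl, which gave a number 0.10 log units higher from compound 1 to compound 3 (within the scatter). That step was within the scatter, so this part of the molecule has so far tolerated a change of the ring without a shift in this assay. Among the measured compounds shown here, no measured step puts a six-membered ring with two nitrogens at this carbon, so the pyrimidin-5-yl change rests on no direct precedent. On that basis a step within the scatter, a number 0.20 log units lower from compound 3 to compound 4 (within the scatter), is expected from the thiophen-2-yl compound to the pyrimidin-5-yl compound. Compound 4 is therefore estimated at 7.4 in this assay, within a range from 6.8 to 8.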

Compound 4, negative logarithm of the antagonist equilibrium constant: 6.9
The estimate for compound 4 lay 0.50 log units above the measured number; low and high end bracket the measured number.
By their numbers in this assay, from the lowest: compound 4; then compounds 1 and 3 (each within the scatter of the next); then compound 2.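

At the aromatic carbon para to a large group, the ring cannot be exchanged freely in this assay: pyrimidin-5-yl gives a number 0.70 log units lower from compound 3 to compound 4 (beyond the scatter) and a number 0.60 log units lower from compound 1 to compound 4 (beyond the scatter). Phenyl and thiophen-2-yl remain interchangeable here, with a number 0.10 log units higher from compound 1 to compound 3 (within the scatter), but that tolerance does not extend to this six-membered aromatic ring with 2 hetero atoms. Nothing measured for these compounds accounts for the drop.

From the compounds shown here alone, it remains open whether a pyridin-3-yl group, with a single ring nitrogen, would stay level with compound 1 and compound 3 or drop to the level of compound 4. Also open, going by these compounds, is whether pyrimidin-5-yl would bring a similar step on the core of compound 2.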